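Cyclobutylmethoxy Replacing Ethylsulfanyl on a Carbonyl Carbon

The source may hold more compounds than are shown below. What is called first, only, known or untested is meant among the compounds shown, and "the series" means these compounds.

Compound 1, `CCN(CC)C(=O)C1=C(C)NC(=O)NC1c1cccs1`: 13%
Compound 2, `CCSC(=O)C1=C(C)NC(=O)NC1c1cccs1`: 6%

Of the compounds shown here, two sharing one core have been measured in an assay on membranes from CHO cells for displacement of a labelled ligand from adenosine receptor A1 (Homo sapiens), read by scintillation counting, with a stated time of 60 min, tested at 1 uM; a higher number here means more inhibition at the concentration tested (going by the name of the read-out), a lower number less inhibition. Compound 1 gives 13% in this assay, and compound 2 gives 6%. For the measured compounds named here, the only step between them is a number 7 percentage points lower from compound 1 to compound 2 (within the scatter), so the two numbers cannot be told apart, and compound 2 stands level with compound 1 rather than apart from it.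

Compound 3, `CC1=C(C(=O)OCC2CCC2)C(c2cccs2)NC(=O)N1`, is not yet measured. It differs from compound 2 in one place: cyclobutylmethoxy in place of ethylsulfanyl on a carbonyl carbon. Going by the values given here, no measured step changes this carbonyl carbon to an oxygen-linked group, so the one step on record, from compound 1 to compound 2, bears on the site but not on the new group, and that step stayed within the scatter. Compound 3 is therefore expected to give 9%, with a range of -8% to 26%. The estimated step of a number 3 percentage points higher from compound 2 to compound 3 (within the scatter) is expected to stay within the scatter.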

Compound 3, a percentage reported as inhibition, at one concentration (the size of the read-out at that concentration, not a potency): 39%
Beside the measured number, compound 3's estimate is 30 percentage points below it; measured number outside the range, above it.
By their numbers in this assay, from the lowest: compounds 2 and 1 (each within the scatter of the next); then compound 3.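

On this carbonyl carbon, the group can make a difference in this assay that goes beyond the scatter, which the step between the two earlier compounds did not show (a number 33 percentage points higher from compound 2 to compound 3 (beyond the scatter)). The cyclobutylmethoxy group also stands clear of diethylamino (a number 26 percentage points higher from compound 1 to compound 3 (beyond the scatter)), so compound 3 is set apart from both earlier compounds, which remain level with each other. Nothing at hand accounts for this higher number.

From the compounds shown here alone, whether the step belongs to the oxygen link or to the four-membered ring stays open, and a plain ethoxy group on the same carbonyl carbon would separate the two. Also open, going by these compounds, is how far the number moves with ring size, which a cyclopentylmethoxy or cyclopropylmethoxy group would test.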